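The compounds below may be only part of what the source reports. "The series", "measured", "known", "first", "only" and "open" are said of these compounds alone.

Compound 3 `C/C(=C\CC/C(C)=C/CC[C@@H]1[C@@]2(C)CCC(=O)C(C)(C)[C@H]2CC[C@@]1(C)O)CC/C=C(\C)C(=O)OCc1cn(-c2ccccc2)nn1` carries a (1-phenyl-1H-1,2,3-triazol-4-yl)methyl ester on the shared core. In a functional assay on DU-145 cells (Homo sapiens) for antiproliferative activity, read by MTT assay, with a stated time of 48 h (on this read-out higher numbers stand for weaker inhibition and lower numbers for stronger inhibition), compound 3 gives 95500 nM, the highest of the two numbers reported here. Compound 1 `C#CCOC(=O)/C(C)=C/CC/C(C)=C/CC/C(C)=C/CC[C@@H]1[C@@]2(C)CCC(=O)C(C)(C)[C@H]2CC[C@@]1(C)O`, with an ethynyl group at the same place, gives 46100 nM in this assay. For compound 2 `C/C(=C\CC/C(C)=C/CC[C@@H]1[C@@]2(C)CCC(=O)C(C)(C)[C@H]2CC[C@@]1(C)O)CC/C=C(\C)C(=O)OCc1cn(-c2cccc(Br)c2)nn1`, which bears 1-(3-bromophenyl)-1H-1,2,3-triazol-4-yl there, this assay reports only a limit, > 150000 nM; this is the limit of > 150000 nM in this assay, at which 1 of the 3 values shown sits. The measured steps run a 2.1-fold higher number from compound 1 to compound 3 (0.32 log units; beyond the scatter), an at least 3.2-fold higher number from compound 1 to compound 2 (0.51 log units; beyond the scatter) and an at least 1.5-fold lower number from compound 2 to compound 3 (0.19 log units; that floor lies within the scatter). Compound 4 `C/C(=C\CC/C(C)=C/CC[C@@H]1[C@@]2(C)CCC(=O)C(C)(C)[C@H]2CC[C@@]1(C)O)CC/C=C(\C)C(=O)O` differs from compound 3 by hydrogen in place of (1-phenyl-1H-1,2,3-triazol-4-yl)methyl on an oxygen next to a carbonyl group. For the measured compounds named here, no measured step removes the whole ester substituent, so the expectation rests only on the observation that compound 1, with its smaller ethynyl group and its value of 46100 nM, sits lower than the triazolyl ester. The step is therefore expected to be a 1.9-fold lower number from compound 3 to compound 4 (0.28 log units; within the scatter), toward a lower number. Compound 4 is estimated at 50000 nM, within 15000 nM to 150000 nM in this assay.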

Compound 4, half-maximal inhibitory concentration: > 150000 nM
Compound 4 was reported as a limit (the forecaster's own chance of this, stated with the estimate: 25%); middle value at least 3.0-fold (0.47 log units) away from the limit.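

Compound 4, with hydrogen on the oxygen next to the carbonyl group, is reported in this assay only as a limit, > 150000 nM. For the compounds shown here, the change from propargyl to hydrogen gives an at least 3.2-fold higher number from compound 1 to compound 4 (0.51 log units; beyond the scatter), so for the first time the free hydrogen is seen to lose ground against the small ester, while an at least 1.5-fold higher number from compound 3 to compound 4 (0.19 log units; that floor lies within the scatter) does not separate hydrogen from (1-phenyl-1H-1,2,3-triazol-4-yl)methyl. Compound 4 thereby joins compound 2 at the same ceiling: the limit of > 150000 nM in this assay, at which 2 of the 4 values shown sit.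

How far compound 4 lies past its limit cannot be read, and no order between compound 4 and compound 2 can be given. On these data alone, whether a methyl group, an ethyl group or a chain ending in an amine on that oxygen would match the lower number of compound 1 remains open.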